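Ring-nitrogen substituent exchange and rat clearance in the series

The source may hold more compounds than are shown below. What is called first, only, known or untested is meant among the compounds shown, and "the series" means these compounds.

Two compounds of the series have numbers in an in vivo ADME assay on the whole organism (strain Han Wistar) for pharmacokinetics, with Rattus norvegicus as the target; a lower number here means slower removal, a higher number faster removal of the compound. Compound 1, `CCCC[C@H](NC(=O)O[C@@H]1C(=O)N(C(=O)c2nnc(C(F)(F)F)s2)CC1(C)C)C(=O)C(=O)Nc1cc[nH]n1`, gives 79 mL/min/kg there. Compound 2, `CCCC[C@H](NC(=O)O[C@@H]1C(=O)N(C(=O)c2ccno2)CC1(C)C)C(=O)C(=O)N[C@H](C)c1ccccc1`, gives 18 mL/min/kg in this assay, the lower of the two numbers, and its gap to compound 1 is beyond the usual scatter. Compound 3, `CCCC[C@H](NC(=O)O[C@@H]1C(=O)N(S(=O)(=O)c2ccccc2)CC1(C)C)C(=O)C(=O)N[C@H](C)c1ccccc1`, has not yet been measured. It differs from compound 2 in one place: phenylsulfonyl in place of (1,2-oxazol-5-yl)carbonyl on an amide-type nitrogen in a ring. Among the compounds with values here, no step between two measured compounds covers this exchange, and neither compound 1 nor compound 2 carries the entering group, so there is nothing to set beside the change other than the bare values of those two compounds. For this assay the step is therefore expected to be a 1.2-fold higher number from compound 2 to compound 3 (0.09 log units; within the scatter), read as no change beyond the scatter, with a slight lean toward a higher number left open. Compound 3 is accordingly estimated to give about 22 mL/min/kg in this assay, within a range from 9 mL/min/kg to 50 mL/min/kg.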

Compound 3, clearance: 27 mL/min/kg
Compound 3: middle estimate off by 1.2-fold (0.09 log units), on the low side, and the stated range covers the measured number.
By their numbers in this assay, from the lowest: compounds 2 and 3 (each within the scatter of the next); then compound 1.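

In this assay, the exchange on the amide-type nitrogen in a ring now has a direct reading, a 1.5-fold higher number from compound 2 to compound 3 (0.18 log units; within the scatter), so the two groups are not separated at this position in this pair. The exchange replaces both the carbonyl link with a sulfonyl link and the five-membered aromatic ring with 2 hetero atoms with a six-membered aromatic ring of carbon only, yet the pair gives no reading beyond the scatter. This single pair offers no explanation for that outcome, and no supporting measurement bears on it.

Benzoyl on the same nitrogen would separate the link from the ring, while methylsulfonyl would test the sulfonyl link without the phenyl ring, so the contribution of each part remains open. Going by these compounds, it also remains open whether the same exchange reads alike when the (1-phenylethyl)amide end of compound 2 is replaced by another amide, such as the pyrazolyl amide end of compound 1, or whether an amine or a carboxylic acid on the phenyl ring of the entering group would move the number beyond the scatter.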